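Cytotoxicity series: replacing the biaryl tail by a benzodioxin

A few compounds are considered here, and "the series" means these few. Any claim that something is new, unique, unknown or untested is made for them only; others in the source may bear on it.

Measured compounds:
- compound 1, `CC(C)N(Cc1cccc(OCCCCCC(=O)O)c1)C(=O)c1ccc(-c2cccc(-c3ccccc3)c2)cc1`: in an ADME assay on BJ cells (Homo sapiens) for cytotoxicity, read by CellTiter-Glo and resazurin assay, with a stated time of 72 h (on this read-out higher numbers stand for an effect only at larger amounts of compound and lower numbers for an effect already at smaller amounts), compound 1 gives a limit, > 26000 nM.
- compound 2, `CC(C)N(Cc1cccc(OCCCCCC(=O)O)c1)C(=O)c1ccc(-c2cccc(S(C)(=O)=O)c2)cc1`: in this assay compound 2 gives a limit, > 26000 nM.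
- compound 3, `CCOC(=O)CCCCCOc1cccc(CN(C(=O)c2ccc(-c3cccc(-c4ccccc4)c3)cc2)C(C)C)c1`: in this assay compound 3 gives a limit, > 26000 nM.

Among the measured compounds shown here, compound 3 thus stands at the same limit as the other two; none of the three gives a number, and the limit of > 26000 nM in this assay, at which 3 of the 3 values shown sit, is the only evidence the set offers.

The next compound is compound 4, `CCOC(=O)CCCCCOc1cccc(CN(C(=O)c2ccc(-c3ccc4c(c3)OCCO4)cc2)C(C)C)c1`. Its difference from compound 3 is 2,3-dihydro-1,4-benzodioxin-6-yl in place of 3-phenylphenyl on an aromatic carbon.

The measured steps are a step that the two limits leave unreadable from compound 1 to compound 2 and a step that the two limits leave unreadable from compound 1 to compound 3; both run from one limit to another, so neither has a readable size. For the measured compounds named here, they tell only that a change at the biaryl end or at the ester end did not pull the value below the limit. For the step to compound 4 no size can therefore be derived; the expectation is that it also stays beyond the limit, estimated as a step that the limit leaves unreadable from compound 3 to compound 4.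

Compound 4 is expected at 40000 nM, with a range from 15000 nM to 150000 nM.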

Compound 4, half-maximal effective concentration: > 24400 nM
Compound 4: only a limit was reported (the forecaster's own chance of this, stated with the estimate: 85%); the middle value does not contradict the limit.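

Compound 3 and compound 4 both give only limits, and the step between them cannot be read. The compounds shown leave open at what concentration any of the four reaches a half-maximal effect, and whether 2,3-dihydro-1,4-benzodioxin-6-yl and 3-phenylphenyl differ at all.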